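The source may report more compounds than this note shows. Statements on the series, on what has been measured and on what is new or still open speak of the compounds shown alone.

Measured so far:
compound 1, `CCCCN(CC)c1nc(C)nc2c1ncn2-c1c(Br)cc(OC)cc1OC`, 3.5 nM
compound 2, `CCCCN(CC)c1nc(C)nc2c1ncn2-c1c(Cl)cc(OC)cc1OC`, 5.2 nM

Compound 1 and compound 2 share one core and differ only in a halogen on the aromatic ring. In an in vitro assay on 293-EBNA cells for binding affinity to corticotropin-releasing factor receptor 1 (Homo sapiens) (a higher number here means a weaker inhibitor, a lower number a stronger inhibitor), compound 1 gives 3.5 nM and compound 2 gives 5.2 nM; the step of a 1.5-fold higher number from compound 1 to compound 2 (0.17 log units; within the scatter) is within the scatter. Compound 2 thus holds the higher of the two numbers, but the gap to compound 1 is within the scatter, so neither can be called the stronger.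

Compound 3, `CCCCN(CC)c1nc(C)nc2c1nc(-c1ccccc1)n2-c1c(Cl)cc(OC)cc1OC`, is not yet measured. It differs from compound 2 by phenyl in place of hydrogen on an aromatic carbon. Within the data shown here, no measured step touches this position: the only step seen is a halogen swap on the aromatic ring, which says nothing about a phenyl entering the core. The expectation for this assay therefore rests on the change alone and is uncertain, with the estimated step of a 2.3-fold higher number from compound 2 to compound 3 (0.36 log units; beyond the scatter) for compound 3 only a guess toward a somewhat higher number. Compound 3 is estimated at 12 nM, with a range from 2.5 nM to 60 nM.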

Compound 3, inhibition constant: 133 nM
The estimate for compound 3 lay 11-fold (1.04 log units) below the measured number; measured number outside the range, above it.
By their numbers in this assay, from the lowest: compounds 1 and 2 (each within the scatter of the next); then compound 3.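

In this assay, phenyl in place of hydrogen on this aromatic carbon of the five-membered ring gives a 26-fold higher number from compound 2 to compound 3 (1.41 log units; beyond the scatter), a large step and the only one shown that lies beyond the scatter. The earlier pair showed only that a chloro and a bromo on an aromatic carbon cannot be told apart; this result shows that the carbon between two ring nitrogen atoms is far less forgiving, at least of phenyl, which leaves compound 3 well behind compound 2. Nothing measured explains why the step is so large.

From the compounds shown here alone, with only hydrogen and phenyl seen at this carbon, it remains open whether the loss appears with any group there or only with one as large as phenyl. A methyl, an amine or a pyridine ring at the same carbon would begin to separate these possibilities.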